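Hydroxy in place of methyl on the aryl group of compound 1

This account rests on a few compounds, and the source may have more. Where it says the series, first, only, none or still open, it means among the compounds named here.

For the measured compounds named here, compound 1 `Cc1ccc([C@]2(CO)NC[C@@H](O)[C@@H]2O)cc1` and its mirror image compound 2 `Cc1ccc([C@@]2(CO)NC[C@H](O)[C@H]2O)cc1` are the two compounds measured so far. Going by the values given here, in an assay on isolated protein for inhibition of alpha-galactosidase (Coffea arabica), tested at 1000 uM (on this read-out lower numbers stand for less inhibition and higher numbers for more inhibition at the one concentration tested (going by the name of the read-out)), compound 1 gives 1.6%, and compound 2 gives 0%, the two numbers lying within the scatter of each other; the step of a number 1.6 percentage points lower from compound 1 to compound 2 (within the scatter) is the only measured step, and it turns on configuration alone (the fact that compounds 1 and 2 differ only in the configuration as drawn). Compound 3 `OC[C@@]1(c2ccc(O)cc2)NC[C@@H](O)[C@@H]1O` differs from compound 1 by hydroxy in place of methyl on an aromatic carbon. Among the compounds with values here, no measured step bears on this change. With compound 1 at 1.6%, compound 3 is expected to give 5%, between 0% and 20%, a step of a number 3.4 percentage points higher from compound 1 to compound 3 (within the scatter) that is not expected to rise beyond the scatter.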

Compound 3, a percentage reported as inhibition, at one concentration (the size of the read-out at that concentration, not a potency): 1.2%
For compound 3 the middle estimate is 3.8 percentage points above the measured one; the range from low to high includes it.
By their numbers in this assay, from the lowest: compounds 2, 3 and 1 (each within the scatter of the next).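

In this assay, for the compounds shown here, hydroxy in place of methyl on the aromatic carbon gives a number 0.4 percentage points lower from compound 1 to compound 3 (within the scatter) and so brings the first reading of a change of group at this position, which is no change beyond the scatter. Since compound 1 starts at only 1.6% at the one concentration tested, this step could hardly show a loss and speaks only against a gain. Nothing at hand bears on this exchange.

From the compounds shown here alone, whether an amine, a carboxylic acid or a longer chain on that aromatic carbon would raise the number beyond the scatter stays open. So does whether hydroxy would read the same on the mirror-image core of compound 2.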